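Acetamidophenyl Replaces Trifluoromethylphenyl on the Triazole Nitrogen

This account rests on a few compounds, and the source may have more. Where it says the series, first, only, none or still open, it means among the compounds named here.

Of the compounds shown here, two of a shared core have been measured in an ADME assay on L02 cells (Homo sapiens) for antiproliferative activity, read by MTT assay, with a stated time of 48 h; a higher number here means a weaker inhibitor, a lower number a stronger inhibitor. Compound 1 `CCc1ccccc1-n1nncc1CN1C(=O)C2(C(C#N)=C(N)Oc3c(N)cc4nc5ccccc5nc4c32)c2ccccc21` gives 22900 nM in this assay. Compound 2 `N#CC1=C(N)Oc2c(N)cc3nc4ccccc4nc3c2C12C(=O)N(Cc1cnnn1-c1cccc(C(F)(F)F)c1)c1ccccc12` gives 38100 nM. Compound 2 stands highest of the two numbers, and its nearest neighbour is compound 1; the step of a 1.7-fold higher number from compound 1 to compound 2 (0.22 log units; within the scatter) exchanged 2-ethylphenyl for 3-(trifluoromethyl)phenyl on an aromatic nitrogen and lies within the scatter.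

Compound 3 `CC(=O)Nc1ccc(-n2nncc2CN2C(=O)C3(C(C#N)=C(N)Oc4c(N)cc5nc6ccccc6nc5c43)c3ccccc32)cc1` has not yet been measured. It differs from compound 2 in one place: 4-acetamidophenyl in place of 3-(trifluoromethyl)phenyl on an aromatic nitrogen. Among the compounds with values here, only one measured step bears on this change, namely a 1.7-fold higher number from compound 1 to compound 2 (0.22 log units; within the scatter), which was within the scatter and also exchanged one aryl group for another on the same aromatic nitrogen. Within the data shown here, nothing among the measured compounds points to a step beyond the scatter in this assay in either direction. The number for compound 3 is therefore expected to stay close to that of compound 2, with an expected step of a 1.1-fold lower number from compound 2 to compound 3 (0.02 log units; within the scatter). Compound 3 is estimated at 36000 nM, within an expected range from 14000 nM to 90000 nM.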

Compound 3, half-maximal inhibitory concentration: > 50000 nM
Compound 3 ended at the assay's limit (the forecaster's own chance of this, stated with the estimate: 10%); at least 1.3-fold (0.14 log units) between middle value and limit.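

In this assay compound 3 gives > 50000 nM, which is a limit of the assay and not a number. Read against the 3-(trifluoromethyl)phenyl group, the change to 4-acetamidophenyl is an at least 1.3-fold higher number from compound 2 to compound 3 (0.11 log units; that floor lies within the scatter), so on that floor alone the two groups cannot be told apart on the aromatic nitrogen, although the true step may be larger. Read against 2-ethylphenyl, the same group gives an at least 2.1-fold higher number from compound 1 to compound 3 (0.33 log units; beyond the scatter), the first step on this nitrogen to pass beyond the scatter, and it shows that the choice of aryl group there can move the number in this assay, which the step between the two earlier compounds could not show.

The compounds shown leave open how far the true number for compound 3 lies past the limit, and whether the acetamido group itself or its place on the phenyl ring matters most. They also cannot tell whether a free amine or a carboxylic acid in place of the acetamido group, or an unsubstituted phenyl ring, would give a number that can be read in this assay.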